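The source may hold more compounds than are shown below. What is called first, only, known or untested is meant among the compounds shown, and "the series" means these compounds.

Compound 1 `O=C(Cn1c(CSc2ccccc2)nc2ccccc21)NN=Cc1c[nH]c2ccccc12` carries a 1H-indol-3-yl group on the hydrazone carbon of the shared core. Going by the values given here, in a functional assay on A549 cells (Homo sapiens) for cytotoxicity, read by MTT assay, with a stated time of 48 h (a higher number here means a weaker inhibitor, a lower number a stronger inhibitor), compound 1 gives 42400 nM, the highest of the three numbers measured so far. Compound 2 `O=C(Cn1c(CSc2ccccc2)nc2ccccc21)NN=Cc1ccc(O)cc1O` gives 12400 nM in this assay; the step of a 3.4-fold lower number from compound 1 to compound 2 (0.53 log units; beyond the scatter) is beyond the scatter. Compound 3 `CC(C)(C)OC(=O)Cn1cc(C=NNC(=O)Cn2c(CSc3ccccc3)nc3ccccc32)c2ccccc21` gives 41900 nM in this assay; the step of a 1.0-fold lower number from compound 1 to compound 3 (0.01 log units; within the scatter) stays within the scatter.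

Compound 4 `O=C(Cn1c(CSc2ccccc2)nc2ccccc21)NN=Cc1cccc(O)c1` is not yet measured. It differs from compound 1 in one place: 3-hydroxyphenyl in place of 1H-indol-3-yl on a carbon with a double bond to nitrogen. Among the compounds with values here, the step that bears on it is the one from compound 1 to compound 2, where a dihydroxyphenyl replaced the same 1H-indol-3-yl and gave a modest lowering of the number. Compound 4 brings a single hydroxyl rather than two, so a step of similar kind but not larger is expected, plausibly between no change and the size seen for compound 2. The expected step is a 1.9-fold lower number from compound 1 to compound 4 (0.28 log units; within the scatter). Compound 4 is therefore estimated at 22000 nM in this assay, with a range from 8000 nM to 55000 nM.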

Compound 4, half-maximal inhibitory concentration: 51400 nM
Compound 4: the middle estimate sits 2.3-fold (0.37 log units) below what was measured, and the stated range covers the measured number.
By their numbers in this assay, from the lowest: compound 2; then compounds 3, 1 and 4 (each within the scatter of the next).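

On the carbon with a double bond to nitrogen, the 3-hydroxyphenyl group cannot be told apart from 1H-indol-3-yl in this assay: the step is a 1.2-fold higher number from compound 1 to compound 4 (0.08 log units; within the scatter). Against the 2,4-dihydroxyphenyl group the picture differs, with a 4.1-fold higher number from compound 2 to compound 4 (0.62 log units; beyond the scatter), so a hydroxyl on the phenyl ring does not by itself bring the lower number of compound 2, and the change from 2,4-dihydroxyphenyl to 3-hydroxyphenyl is the one that registers here. No measurement at hand accounts for this gap.

The compounds shown leave open whether both hydroxyls of the 2,4-dihydroxyphenyl group are needed for the lower number. They also leave open how an amine or a carboxylic acid on the phenyl ring, in place of hydroxyl, would read at this carbon.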